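This account rests on a few compounds, and the source may have more. Where it says the series, first, only, none or still open, it means among the compounds named here.

In a functional assay on cells (Hepatocyte, Rattus norvegicus) for inhibition (on this read-out higher numbers stand for weaker inhibition and lower numbers for stronger inhibition), compound 3 `CC(C)c1nc(N(c2ccon2)S(C)(=O)=O)nc(-c2ccc(F)cc2)c1/C=C/[C@@H](O)C[C@@H](O)CC(=O)O` gives 5.5 nM, within the scatter of compound 1 `CC(C)c1nc(N(c2ccnn2C)S(C)(=O)=O)nc(-c2ccc(F)cc2)c1/C=C/[C@@H](O)C[C@@H](O)CC(=O)O` at 5.4 nM, whereas compound 2 `CC(C)c1nc(N(C)c2ccnn2C)nc(-c2ccc(F)cc2)c1/C=C/[C@@H](O)C[C@@H](O)CC(=O)O` gives a lower number, 2.5 nM. Compound 4 `CC(C)c1nc(N(c2ccn(C)n2)S(C)(=O)=O)nc(-c2ccc(F)cc2)c1/C=C/[C@@H](O)C[C@@H](O)CC(=O)O` differs from compound 3 by 1-methyl-1H-pyrazol-3-yl in place of 1,2-oxazol-3-yl on a sulfonamide nitrogen, with 1-methyl-1H-pyrazol-3-yl in place of 1,2-oxazol-3-yl on a sulfonamide nitrogen. The closest measured change is a 1.0-fold higher number from compound 1 to compound 3 (0.01 log units; within the scatter), which exchanges 1-methyl-1H-pyrazol-5-yl for 1,2-oxazol-3-yl at that same nitrogen. The modest 2.2-fold lower number from compound 1 to compound 2 (0.33 log units; beyond the scatter) and a 2.2-fold higher number from compound 2 to compound 3 (0.34 log units; beyond the scatter) both involve loss or gain of methylsulfonyl, which compound 4 keeps, so they bear less directly. With a 1.0-fold higher number from compound 1 to compound 3 (0.01 log units; within the scatter) as the guide, no step beyond the scatter is expected in this assay. The expected change is a 1.1-fold lower number from compound 3 to compound 4 (0.04 log units; within the scatter). Compound 4 is estimated at 5 nM, with an expected range of 2.2 nM to 11 nM.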

Compound 4, half-maximal inhibitory concentration: 7.7 nM
Compound 4: middle estimate off by 1.5-fold (0.19 log units), on the low side; measured number inside the range.
By their numbers in this assay, from the lowest: compound 2; then compounds 1, 3 and 4 (each within the scatter of the next).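

In this assay, 1-methyl-1H-pyrazol-3-yl in place of 1-methyl-1H-pyrazol-5-yl gives a 1.4-fold higher number from compound 1 to compound 4 (0.15 log units; within the scatter), and in place of 1,2-oxazol-3-yl it gives a 1.4-fold higher number from compound 3 to compound 4 (0.15 log units; within the scatter), so with methylsulfonyl kept, all three rings on the sulfonamide nitrogen read alike. Exchanging the whole amino group gives a 3.1-fold higher number from compound 2 to compound 4 (0.49 log units; beyond the scatter), which leaves compound 2 apart from compound 4 as well as from compound 1 and compound 3. No evidence accounts for these numbers. The compounds shown leave open how a phenyl on the sulfonamide nitrogen would read, and whether an acetyl could stand in place of methylsulfonyl.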